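This account rests on a few compounds, and the source may have more. Where it says the series, first, only, none or still open, it means among the compounds named here.

Measured so far:
- compound 1 `COc1ccc(-c2cc3cccc(OC)c3nc2O)cc1`: 10000 nM
- compound 2 `CCOC(=O)Cn1c(=O)c(-c2ccc(OC)cc2)cc2c(OC)cc(OC)cc21`: 10000 nM

In a functional assay on A 172 cells (Homo sapiens) for cytotoxicity, read by colorimetric assay and MTT assay (a higher number here means a weaker inhibitor, a lower number a stronger inhibitor), compound 2 gives 10000 nM, level with compound 1 at 10000 nM within the scatter. Compound 3 `COc1ccc(-c2cc3c(OC)cc(OC)cc3n(CC#N)c2=O)cc1` differs from compound 2 in one place: cyano in place of ethoxycarbonyl on a saturated chain carbon bound to an aromatic nitrogen. Going by the values given here, no measured step covers this change, so the direction is open. The expected change a 1.3-fold lower number from compound 2 to compound 3 (0.10 log units; within the scatter) stays within the scatter. Compound 3 is estimated at 8000 nM, with an expected range of 2500 nM to 20000 nM.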

Compound 3, half-maximal inhibitory concentration: 10000 nM
Beside the measured number, compound 3's estimate is 1.3-fold (0.10 log units) below it; the range from low to high includes it.
By their numbers in this assay, from the lowest: compounds 1, 2 and 3 (each within the scatter of the next).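

In this assay, cyano in place of ethoxycarbonyl on a saturated chain carbon bound to an aromatic nitrogen gives no change at the digits printed from compound 2 to compound 3 (within the scatter). Going by these compounds alone, this is the first step read at this position, and it shows that exchanging the larger ethoxycarbonyl for cyano, with the carbonyl gone, does not shift the number. Nothing on hand bears on this result.

From the compounds shown here alone, whether a carboxylic acid, an amine or a longer chain at this position would move the number away from that of compound 3 at 10000 nM remains open.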